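Replacing ethoxy by chloro on the thiosemicarbazone aryl ring

This account rests on a few compounds, and the source may have more. Where it says the series, first, only, none or still open, it means among the compounds named here.

Of the compounds shown here, three sharing one core have been measured in a functional assay on MDA-MB-231 cells (Homo sapiens) for inhibition, read by WST assay, with a stated time of 48 h; on this read-out higher numbers stand for weaker inhibition and lower numbers for stronger inhibition. Compound 1 `Oc1cccc(/C=N\NC(=S)NC2CCCCC2)c1` gives 24500 nM, compound 2 `COc1cccc(/C=N\NC(=S)NC2CCCCC2)c1` gives 88900 nM, and compound 3 `CCOc1ccc(/C=N\NC(=S)NC2CCCCC2)cc1` gives 68200 nM. Compound 3 stands second highest of the three numbers; its nearest neighbour is compound 2, within the scatter, while compound 1 lies beyond the scatter below it. Among the measured compounds shown here, the only single-site step known, a 3.6-fold higher number from compound 1 to compound 2 (0.56 log units; beyond the scatter), concerns methyl in place of hydrogen on an oxygen and is modest.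

Compound 4 `S=C(N/N=C\c1ccc(Cl)cc1)NC1CCCCC1` differs from compound 3 as follows: chloro in place of ethoxy on an aromatic carbon. For the measured compounds named here, no measured step involves chloro or the loss of an ethoxy group, so the known step gives only indirect guidance: both alkoxy compounds sit at the weak end, and compound 1, with a free hydroxyl, is the one beyond the scatter below them. The change in compound 4 is therefore expected to give a step of a 1.5-fold lower number from compound 3 to compound 4 (0.18 log units; within the scatter) in this assay, small and uncertain in direction. Compound 4 is estimated at 45000 nM, with a range from 15000 nM to 130000 nM.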

Compound 4, half-maximal inhibitory concentration: 38300 nM
Compound 4: the middle estimate sits 1.2-fold (0.07 log units) above what was measured; measured number inside the range.
By their numbers in this assay, from the lowest: compounds 1, 4, 3 and 2 (each within the scatter of the next, the first and the last beyond it).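

In this assay the swap of ethoxy for chloro gives a 1.8-fold lower number from compound 3 to compound 4 (0.25 log units; within the scatter) and so stays within the scatter. Unlike the earlier step, which altered only the group on an oxygen, this change removes the whole ethoxy group from the aromatic carbon para to a large group, and its three heavy atoms and one hydrogen-bond acceptor give way to a single chlorine with no step beyond the scatter. No measurement shown here accounts for this result.

Going by these compounds, what remains open is whether this position stays as permissive for a different kind of group, such as an amine, a carboxylic acid or a longer alkoxy chain. On these data alone, it is also open whether a hydroxyl on this same aromatic carbon would stand nearer to compound 1 than to compound 3.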